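This account rests on a few compounds, and the source may have more. Where it says the series, first, only, none or still open, it means among the compounds named here.

Measured compounds:
Compound 1 `Cc1ccc(-n2c(-c3coc4cc(C)c(Cl)cc4c3=O)nc(-c3ccccc3)c2-c2ccccc2)cc1`: 6250 nM
Compound 2 `Cc1cc2occ(-c3nc(-c4ccccc4)c(-c4ccccc4)n3-c3ccc([N+](=O)[O-])cc3)c(=O)c2cc1Cl`: 25000 nM

In a functional assay on HepG2 cells (Homo sapiens) for inhibition, read by MTT assay, with a stated time of 72 h (on this read-out higher numbers stand for weaker inhibition and lower numbers for stronger inhibition), compound 2 gives the highest of the two numbers; its nearest neighbour is compound 1, and the step is a 4.0-fold higher number from compound 1 to compound 2 (0.60 log units; beyond the scatter). Compound 3 `Cc1cccc(-n2c(-c3coc4cc(C)c(Cl)cc4c3=O)nc(-c3ccccc3)c2-c2ccccc2)c1` differs from compound 2 in one place: 3-methylphenyl in place of 4-nitrophenyl on an aromatic nitrogen. Going by the values given here, the only measured step, a 4.0-fold higher number from compound 1 to compound 2 (0.60 log units; beyond the scatter), runs the other way, swapping methyl for nitro, so the change here is expected to roughly undo it, though 3-methylphenyl is not the same group as in compound 1. A lowering of about that size is therefore expected in this assay. Compound 3 is estimated at 7000 nM, between 3000 nM and 16000 nM, which is an expected step of a 3.6-fold lower number from compound 2 to compound 3 (0.55 log units; beyond the scatter).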

Compound 3, half-maximal inhibitory concentration: 6250 nM
Compound 3: the middle estimate sits 1.1-fold (0.05 log units) above what was measured; the range from low to high includes it.
By their numbers in this assay, from the lowest: compounds 1 and 3 (each within the scatter of the next); then compound 2.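

In this assay 3-methylphenyl and 4-methylphenyl on the aromatic nitrogen are interchangeable, with (no change at the digits printed from compound 1 to compound 3 (within the scatter)). The swap away from 4-nitrophenyl gives (a 4.0-fold lower number from compound 2 to compound 3 (0.60 log units; beyond the scatter)), so among these three compounds the number tracks whether the ring carries nitro or methyl, and the two methyl placements do not separate. Nothing measured here explains why.

Still open, as far as these compounds go, is how 3-nitrophenyl would compare with 4-nitrophenyl. Also open, from the compounds shown here alone, is how an amine, a carboxylic acid or a longer chain on this ring would read.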